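This account rests on a few compounds, and the source may have more. Where it says the series, first, only, none or still open, it means among the compounds named here.

The series shares one core, and the variable part is the aryl group carried on an aromatic carbon. Compound 1 `COc1ccccc1-c1cccc(S(=O)(=O)N2CCC(N3CCC(C)CC3)CC2)c1` gives 21 nM in a functional assay on DLD-1 cells (Homo sapiens) for antiproliferative activity, read by CellTiter-Glo, with a stated time of 72 h; a lower number here means a stronger inhibitor, a higher number a weaker inhibitor. For the measured compounds named here, compound 2 `CC1CCN(C2CCN(S(=O)(=O)c3cccc(-c4ccc(Cl)cc4)c3)CC2)CC1` gives 15 nM in this assay; among the two numbers so far compound 2 holds the lower one, yet the step of a 1.4-fold lower number from compound 1 to compound 2 (0.15 log units; within the scatter) leaves the pair within the scatter, so neither compound is set apart from the other. Compound 3 `CC1CCN(C2CCN(S(=O)(=O)c3cccc(-c4ccccc4C(F)(F)F)c3)CC2)CC1` has not yet been measured. It differs from compound 2 in one place: 2-(trifluoromethyl)phenyl in place of 4-chlorophenyl on an aromatic carbon. Going by the values given here, the only measured step that bears on this change is a 1.4-fold lower number from compound 1 to compound 2 (0.15 log units; within the scatter), which stayed within the scatter; the change to compound 3 is of the same kind, an exchange of the aryl group sitting meta to a large group, and nothing on hand points to a move beyond the scatter in either direction of this assay. The step expected here is therefore small, a 1.7-fold higher number from compound 2 to compound 3 (0.22 log units; within the scatter). Compound 3 is estimated at 25 nM in this assay, with a likely range from 8 nM to 80 nM.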

Compound 3, half-maximal inhibitory concentration: 10 nM
The estimate for compound 3 lay 2.5-fold (0.40 log units) above the measured number; the measured number falls inside the stated range.
By their numbers in this assay, from the lowest: compounds 3, 2 and 1 (each within the scatter of the next, the first and the last beyond it).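

In this assay, the position on an aromatic carbon meta to a large group now accommodates a third aryl group, with 2-(trifluoromethyl)phenyl entering for 4-chlorophenyl: a 1.5-fold lower number from compound 2 to compound 3 (0.18 log units; within the scatter) leaves this exchange inside the scatter, so compound 2 and compound 3 cannot be told apart here. For the compounds shown here, the substituent on the aryl group gives the first step that clears the scatter, trifluoromethyl in place of methoxy: a 2.1-fold lower number from compound 1 to compound 3 (0.32 log units; beyond the scatter) is a modest step, and it remains the only reading that separates two compounds. Nothing on hand explains either step, so the three numbers describe the change without accounting for it.

Open, from the compounds shown here alone, is whether this position holds its numbers only with a substituted phenyl, or also with an aryl group carrying an amine, a carboxylic acid or a nitrile. Also open, going by these compounds, is whether the trifluoromethyl result depends on where that group sits, which a 4-(trifluoromethyl)phenyl analogue set against compound 3 would address.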